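Cyano in Place of Methoxy: Expecting the Binding Result

This account rests on a few compounds, and the source may have more. Where it says the series, first, only, none or still open, it means among the compounds named here.

Compound 1, `COc1ccc(/C=C2\CCN=C2c2cccnc2)cc1`: 31.4%
Compound 2, `COc1cccc(/C=C2\CCN=C2c2cccnc2)c1`: 23.6%

Both measured compounds were tested in an assay for displacement of a labelled ligand from Nicotinic acetylcholine receptor alpha8 subunit (Periplaneta americana), read by scintillation counting, with a stated time of 2 h, at 24 degrees C, tested at 10 uM; a higher number here means more inhibition at the concentration tested (going by the name of the read-out), a lower number less inhibition. Compound 1 gives 31.4%, and compound 2 gives 23.6%. Compound 1 stands at the top of these two numbers, yet its gap to compound 2 lies within the usual scatter of such measurements, so the two cannot be told apart on the evidence shown.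

The next compound, compound 3, `N#Cc1ccc(/C=C2\CCN=C2c2cccnc2)cc1`, is built from compound 1 by one change: cyano in place of methoxy on an aromatic carbon. Among the measured compounds shown here, neither measured compound differs from another in a single place, so there is no measured step that could show how large an effect such a swap produces here. For the measured compounds named here, the only anchor is the value of compound 1 itself.

With no guide to direction, the step of a number 4.4 percentage points lower from compound 1 to compound 3 (within the scatter) is expected to stay within the scatter, in no clear direction. In this assay compound 3 is therefore estimated at 27%, with a likely range from 8% to 48%.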

Compound 3, a percentage reported as inhibition, at one concentration (the size of the read-out at that concentration, not a potency): 31.4%
Compound 3: the middle estimate sits 4.4 percentage points below what was measured; the measured number falls inside the stated range.
By their numbers in this assay, from the lowest: compounds 2, 1 and 3 (each within the scatter of the next).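

Among the compounds shown here, the swap of cyano in place of methoxy gives the first measured step between two compounds that differ in one place in this assay (no change at the digits printed from compound 1 to compound 3 (within the scatter)). At this position, on an aromatic carbon para to a large group, one group of 2 heavy atoms and 1 hydrogen-bond acceptor can therefore replace another with the same counts, with no difference that can be told from scatter. No accompanying measurement offers an explanation for this result.

Going by these compounds, it remains open whether a group of another kind on this same aromatic carbon, such as an amine, a carboxylic acid or a longer chain, would move the number beyond the scatter. This single step also leaves open whether cyano in place of methoxy would give the same result elsewhere on the shared core.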